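Cyclobutyl in Place of Propyl on a Shared Amide

The compounds below may be only part of what the source reports. "The series", "measured", "known", "first", "only" and "open" are said of these compounds alone.

Three compounds have measured values in an assay on CHO cells for displacement of a labelled ligand from adenosine receptor A1 (Homo sapiens), read by scintillation counting, with a stated time of 1 h, tested at 1 uM; on this read-out lower numbers stand for less inhibition and higher numbers for more inhibition at the one concentration tested (going by the name of the read-out). Compound 1 `COc1cc(-c2cnc(N)nc2-c2ccccc2)cc(OC)c1OC` gives 56%, and compound 2 `Nc1ncc(-c2ccccc2)c(-c2ccco2)n1` gives 26%. Compound 3 `CCCC(=O)Nc1ncc(-c2cccc(Cl)c2)c(-c2ccccc2)n1` is recorded only as > 80%, which is a limit of this assay rather than a number. Among the three values, (the limit of > 80% in this assay, at which 1 of the 3 values shown sits). Compound 4 `O=C(Nc1ncc(-c2cccc(Cl)c2)c(-c2ccccc2)n1)C1CCC1` differs from compound 3 in one place only: cyclobutyl in place of propyl on a carbonyl carbon. Within the data shown here, no measured pair differs in just this way, so the size of the step cannot be read from the data. The expected step is a step that the limit leaves unreadable from compound 3 to compound 4, small and within the usual scatter. Compound 4 is therefore estimated at 85%, in the range 70% to 95%, most likely again reported as a limit.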

Compound 4, a percentage reported as inhibition, at one concentration (the size of the read-out at that concentration, not a potency): 52%
The estimate for compound 4 lay 33 percentage points above the measured number, outside the stated range (below it).
By their numbers in this assay, from the lowest: compound 2; then compounds 4 and 1 (each within the scatter of the next). At a limit, above all of these: compound 3.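

In this assay, cyclobutyl in place of propyl on a carbonyl carbon gives a number at least 28 percentage points lower from compound 3 to compound 4 (beyond the scatter), so this amide group is a place where one small change in the carbon group alters the read-out. Compound 3 is recorded only at a limit, so the full size of this step cannot be read: the limit of > 80% in this assay, at which 1 of the 4 values shown sits.

The compounds shown leave open whether the ring or the added carbon accounts for the fall. A butyl chain or a cyclopropyl group on the same carbonyl would help to separate the two.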